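Swapping chloro for methoxy in compound 3

A few compounds are considered here, and "the series" means these few. Any claim that something is new, unique, unknown or untested is made for them only; others in the source may bear on it.

In a functional assay on KB cells (Homo sapiens) for antiproliferative activity, read by colorimetric assay and MTT assay (a higher number here means a weaker inhibitor, a lower number a stronger inhibitor), compound 3 `Nc1ccc(S(=O)(=O)Nc2ccc(Cl)c3c(Cl)c[nH]c23)cc1` gives 14 ug/mL and compound 2 `N#Cc1ccc(S(=O)(=O)Nc2ccc(Cl)c3c(Cl)c[nH]c23)cc1` gives 13 ug/mL, so these two sit level. Compound 1 `O=S(=O)(Nc1cccc2cc(O)[nH]c12)c1ccc(Cl)cc1` gives 1.1 ug/mL, a clearly lower number than either of them.

The next compound to be tested, compound 4 `COc1ccc(NS(=O)(=O)c2ccc(N)cc2)c2[nH]cc(Cl)c12`, differs from compound 3 in a single place: methoxy in place of chloro on an aromatic carbon. This is methoxy in place of chloro on an aromatic carbon, para to a large group.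

Among the compounds with values here, only one measured step is available, a 1.1-fold higher number from compound 2 to compound 3 (0.03 log units; within the scatter), which is amino in place of cyano on an aromatic carbon. Within the data shown here, it lies within the scatter, but it concerns a different group, and no measured step replaces a chloro. It therefore offers only a weak guide, and the data favour no direction in this assay. The expected change is a 1.4-fold lower number from compound 3 to compound 4 (0.15 log units; within the scatter), which would not go beyond the scatter. For compound 4 the estimated value is 10 ug/mL, with an expected range from 3 ug/mL to 30 ug/mL.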

Compound 4, half-maximal inhibitory concentration: 20 ug/mL
Estimate against measurement, compound 4: 2.0-fold (0.30 log units) below, and the stated range covers the measured number.
By their numbers in this assay, from the lowest: compound 1; then compounds 2, 3 and 4 (each within the scatter of the next).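

In this assay, methoxy in place of chloro, para to a large group, gives a 1.4-fold higher number from compound 3 to compound 4 (0.15 log units; within the scatter). Within the data shown here, this is the first measured replacement of a chloro here, and it shows that this aromatic carbon can carry methoxy, with its two heavy atoms and one hydrogen-bond acceptor, instead of a single chlorine without a step beyond the scatter; the earlier step, a 1.1-fold higher number from compound 2 to compound 3 (0.03 log units; within the scatter), concerned a different group and could not show this. Nothing measured here offers a reason for this level result. The compounds shown leave open how this carbon would respond to a carboxylic acid or to a longer chain such as butoxy. They also leave open whether the same swap would read alike on the core of compound 1, which differs from compound 3 in more than one place.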